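This account rests on a few compounds, and the source may have more. Where it says the series, first, only, none or still open, it means among the compounds named here.

For the measured compounds named here, in a functional assay on A549 cells (Homo sapiens) for inhibition, read by CCK-8 assay, with a stated time of 48 h (a higher number here means a weaker inhibitor, a lower number a stronger inhibitor), compound 1 (`COc1cc(-c2ccnc3cc(-c4ccc(C(C)=O)cc4)nn23)cc(OC)c1OC`) gives 4100 nM and compound 2 (`COc1ccc(-c2cc3nccc(-c4cc(OC)c(OC)c(OC)c4)n3n2)cc1`) gives 376 nM, the lower of the two numbers so far. Compound 3 (`COc1cc(-c2ccnc3cc(-c4ccc(-c5cnn(C)c5)cc4)nn23)cc(OC)c1OC`) keeps the shared core and carries 1-methyl-1H-pyrazol-4-yl in place of methoxy on an aromatic carbon of the six-membered aromatic ring of carbon only, para to a large group: 1-methyl-1H-pyrazol-4-yl in place of methoxy on an aromatic carbon. Going by the values given here, one measured step bears on this place: an 11-fold lower number from compound 1 to compound 2 (1.04 log units; beyond the scatter), large and beyond the scatter, with methoxy in place of acetyl. Among the compounds with values here, that step shows that the number can move strongly with the group here, but no measured compound carries a pyrazole. A moderate move toward a higher number is therefore expected, smaller than that one step. The expected change is a 1.6-fold higher number from compound 2 to compound 3 (0.20 log units; within the scatter). For compound 3 the estimated value is 600 nM, with an expected range of 100 nM to 3000 nM.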

Compound 3, half-maximal inhibitory concentration: 1150 nM
Compound 3: middle estimate off by 1.9-fold (0.28 log units), on the low side; measured number inside the range.
By their numbers in this assay, from the lowest: compound 2; then compound 3; then compound 1.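

On the six-membered aromatic ring of carbon only, para to a large group, 1-methyl-1H-pyrazol-4-yl in place of methoxy gives a 3.1-fold higher number from compound 2 to compound 3 (0.49 log units; beyond the scatter) in this assay, while the same group in place of acetyl gives a 3.6-fold lower number from compound 1 to compound 3 (0.55 log units; beyond the scatter) in the same assay. The three groups therefore fall in the order methoxy, 1-methyl-1H-pyrazol-4-yl, acetyl from the lowest number to the highest, and the added five-membered aromatic ring places compound 3 between compound 2 and compound 1 rather than beyond either. No measurement shown here accounts for this order.

The compounds shown leave open how a primary amine or a carboxylic acid at this position would compare with methoxy. They also leave open whether a pyrazole lacking the methyl group would give a number different from that of compound 3.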